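Bromo for Methyl: Aortic Readings in Two Series

The compounds below may be only part of what the source reports. "The series", "measured", "known", "first", "only" and "open" are said of these compounds alone.

Measured in a functional assay on thoracic aorta (Rattus norvegicus, strain Wistar), with a stated time of 15 min; on this read-out higher numbers stand for an effect only at larger amounts of compound and lower numbers for an effect already at smaller amounts:
Compound 1, `CC(NC(=O)N(C)S(=O)(=O)c1ccc(Cl)cc1)c1cc(Br)ccc1OCc1ccccc1`: 146000 nM
Compound 2, `Cc1ccc(OCc2ccccc2)c(C(C)NC(=O)N(C)S(=O)(=O)c2ccc(Cl)cc2)c1`: 142000 nM
Compound 3, `Cc1ccc(S(=O)(=O)NC(=O)NC(C)c2cc(C)ccc2OCc2ccccc2)cc1`: 91900 nM

Compound 4, `Cc1ccc(S(=O)(=O)NC(=O)NC(C)c2cc(Br)ccc2OCc2ccccc2)cc1`, has not yet been measured in this assay. It differs from compound 3 by bromo in place of methyl on an aromatic carbon. The same kind of change separates compound 2 from compound 1, where it is bromo in place of methyl on an aromatic carbon, and the description of the place is word for word the same in both cases. How the core of compound 3 differs from that of compound 2 is not broken down here. In the measured pair, the change gave a 1.0-fold higher number from compound 2 to compound 1 (0.01 log units; within the scatter). The three measured values all lie within the usual scatter of one another, so none of them is set above or below the others. Among the measured compounds shown here, the step expected from compound 3 to compound 4 is estimated at a 1.0-fold higher number from compound 3 to compound 4 (0.01 log units; within the scatter), because the one recorded instance of this change gave a 1.0-fold higher number from compound 2 to compound 1 (0.01 log units; within the scatter). The estimate for compound 4 is therefore 94000 nM, with a range expected from 42000 nM to 210000 nM.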

Compound 4, half-maximal effective concentration: 138000 nM
Beside the measured number, compound 4's estimate is 1.5-fold (0.17 log units) below it; the measured number falls inside the stated range.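

In this assay, the step for bromo in place of methyl on an aromatic carbon is a 1.5-fold higher number from compound 3 to compound 4 (0.18 log units; within the scatter), and set beside the earlier pair it agrees with that pair: the same change on two cores in this assay, a 1.0-fold higher number (0.01 log units; within the scatter) from compound 2 to compound 1 and a 1.5-fold higher number (0.18 log units; within the scatter) from compound 3 to compound 4, 1.5-fold (0.16 log units) apart, within the scatter of two such steps. The change therefore carries over from one core to the other without a detectable difference in its size, and in neither pair does it move the reading beyond the usual scatter. This does not show that bromo and methyl are interchangeable across the series, since it rests on two pairs only, and steps this small cannot reveal a modest dependence on the core or say anything about other cores.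

The compounds shown leave open how this read-out would respond to other groups on that aromatic carbon, such as a nitrile or a methoxy group. They also leave open whether a hydroxy group or a longer alkoxy chain in place of the benzyloxy group would give a reading outside the scatter of these values.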